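The source may hold more compounds than are shown below. What is called first, only, known or untested is meant among the compounds shown, and "the series" means these compounds.

In an ADME assay on MRC5 cells (Homo sapiens) for antiproliferative activity, with a stated time of 69 h (a lower number here means that less compound is needed, a higher number that more compound is needed for the effect), compound 1 `Cc1nn(C)c(C)c1NS(=O)(=O)c1c(Cl)cc(C#CCN2CCN(C)CC2)cc1Cl` gives > 50000 nM as a limit of the assay and not as a number. Compound 2 `Cc1nn(C)c(C)c1NS(=O)(=O)c1c(Cl)cc(Br)cc1Cl` gives > 50000 nM as a limit too, not as a number. Going by the values given here, compound 2 therefore has no exact position on the scale, and the only other value available is also a limit, as the limit of > 50000 nM in this assay, at which 2 of the 2 values shown sit, records. Among the compounds with values here, the single measured step is a step that the two limits leave unreadable from compound 1 to compound 2 and it offers no size that could be carried forward. It also concerns a different place on the molecule from the next change.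

Compound 3 `Cc1nn(C)c(C)c1N(C)S(=O)(=O)c1c(Cl)cc(Br)cc1Cl` differs from compound 2 by one small edit, (methyl in place of hydrogen on a sulfonamide nitrogen), which is methyl in place of hydrogen on a sulfonamide nitrogen. Within the data shown here, no measured step bears on this change, so its size cannot be read from the data. No shift beyond the usual scatter is expected in this assay, and no direction can be argued, although another limit is a likely outcome. The expected step is a number no higher from compound 2 to compound 3 (the limit leaves the size open) and rests on this absence of any readable trend. For compound 3 the estimated value is 50000 nM with an expected range from 25000 nM to 100000 nM in this assay.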

Compound 3, half-maximal effective concentration: 27200 nM
Estimate against measurement, compound 3: 1.8-fold (0.26 log units) above; low and high end bracket the measured number.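

In this assay, going by these compounds alone, compound 3 is the only compound here that gives a number rather than a limit, which makes the sulfonamide nitrogen the one place on the molecule where a change can be sized at all. Methyl in place of hydrogen at this nitrogen gives an at least 1.8-fold lower number from compound 2 to compound 3 (0.26 log units; that floor lies within the scatter), and this size is only a floor, as the step starts from a limit, so the real step could be larger, while the floor alone does not go past the usual scatter. The scale therefore holds a single number so far, and the other values remain at one shared limit: the limit of > 50000 nM in this assay, at which 2 of the 3 values shown sit.

As far as these compounds go, whether an ethyl or a longer chain on the sulfonamide nitrogen would give a lower number, a similar one or a limit again stays open. Also open, from the compounds shown here alone, is whether an amine in place of the bromo, or the 3-(4-methylpiperazin-1-yl)prop-1-yn-1-yl group of compound 1, would give a readable number when the sulfonamide nitrogen carries a methyl.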